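Bromo to fluoro on a shared core: two halogen swaps

This account rests on a few compounds, and the source may have more. Where it says the series, first, only, none or still open, it means among the compounds named here.

Measured compounds:
compound 1, `O=C(Nc1ccc(C(F)(F)F)cc1)c1cc(F)ccc1O`: 2090 nM
compound 2, `O=C(Nc1ccc(C(F)(F)F)cc1)c1ccc(Br)cc1O`: 690 nM
compound 3, `O=C(Nc1ccc(C(F)(F)F)cc1)c1cc(Br)ccc1O`: 1090 nM

The three measured compounds share one core and differ only in which halogen sits on it and where it sits. In a functional assay on NALM-6 cells (Homo sapiens) for cytotoxicity, read by luminescence and CellTiter-Glo, with a stated time of 3 days (a lower number here means a stronger inhibitor, a higher number a weaker inhibitor), compound 2 gives 690 nM, compound 3 gives 1090 nM, and compound 1 gives 2090 nM. Compound 2 has the lowest of the three numbers; its gap to compound 3 lies within the scatter, while its gap to compound 1 lies beyond it. How the core of compound 2 differs from that of compound 3 is not broken down here: the two have the same atoms, joined differently.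

One change is already measured: fluoro in place of bromo on an aromatic carbon. That step, a 1.9-fold higher number from compound 3 to compound 1 (0.28 log units; within the scatter), lies within the scatter. The same kind of change leads from compound 2 to the unmeasured compound 4, `O=C(Nc1ccc(C(F)(F)F)cc1)c1ccc(F)cc1O`: fluoro in place of bromo on an aromatic carbon. The place is not quite the same: in compound 3 the swapped atom sits meta to a large group and para to a hydroxy group, while in compound 2 it sits meta to a hydroxy group and para to a large group.

Within the data shown here, the one measured example of this change, a 1.9-fold higher number from compound 3 to compound 1 (0.28 log units; within the scatter), moved the number only a little, so a similar, small step is expected here. Compound 4 is expected to give 1200 nM in this assay. This estimate means a step of a 1.7-fold higher number from compound 2 to compound 4 (0.24 log units; within the scatter), expected to be about as large as a 1.9-fold higher number from compound 3 to compound 1 (0.28 log units; within the scatter). The expected range for compound 4 runs from 500 nM to 3000 nM.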

Compound 4, half-maximal inhibitory concentration: 1530 nM
Compound 4: the middle estimate sits 1.3-fold (0.11 log units) below what was measured, within the range that was stated.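

In this assay, among these compounds, putting fluoro in place of bromo gives a 2.2-fold higher number from compound 2 to compound 4 (0.35 log units; beyond the scatter), and the earlier example of the same swap on the other core agrees with it in direction and in size: the same change on two cores in this assay, a 1.9-fold higher number (0.28 log units; within the scatter) from compound 3 to compound 1 and a 2.2-fold higher number (0.35 log units; beyond the scatter) from compound 2 to compound 4, 1.2-fold (0.06 log units) apart, within the scatter of two such steps So within this small set, the change carries over from one core to the other: the number rises on both, even though only the step on the core of compound 2 passes the scatter by itself. Still, two examples with one pair of halogens in one cell assay make no general rule, and they show neither why the number rises nor how the swap would behave on any core beyond these two.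

The compounds shown leave open how other groups would fare on the same aromatic carbon, such as chloro, a methyl group, a nitrile or an amine, and so whether bromo and fluoro are simply two points on a wider trend. Also open, as far as these compounds go, is what would happen to the number on either core if the hydroxy group gave way to a methoxy group or the trifluoromethyl group to a carboxylic acid.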